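Adding propyl to the ring nitrogen of compound 2

The compounds below may be only part of what the source reports. "The series", "measured", "known", "first", "only" and "open" are said of these compounds alone.

Values measured so far in a functional assay on the whole organism with Mus musculus as the target; a higher number here means that more compound is needed for the effect, a lower number that less compound is needed
compound 1 (`O=C(/C=C/c1cccc(C(F)(F)F)c1)NCCO`) gives 100 mg/kg
compound 2 (`O=C1CCC(O)(c2cccc(C(F)(F)F)c2)N1`) gives > 200 mg/kg

For compound 2 the value (> 200 mg/kg) is a limit of the assay and not a number. Compound 3 (`CCCN1C(=O)CCC1(O)c1cccc(C(F)(F)F)c1`) carries propyl in place of hydrogen on an amide-type nitrogen in a ring. Among the measured compounds shown here, no measured step covers this change. For the measured compounds named here, the only number is that of compound 1 (100 mg/kg). A modest expected move toward a lower dose is therefore assumed (an at least 1.6-fold lower number from compound 2 to compound 3 (0.22 log units; that floor lies within the scatter)). For compound 3 the estimated dose is 120 mg/kg (expected range 50 mg/kg to 280 mg/kg).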

Compound 3, dose for half-maximal effect: 150 mg/kg
For compound 3 the middle estimate is 1.3-fold (0.10 log units) below the measured one, and the stated range covers the measured number.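

In this assay, propyl on the amide-type nitrogen yields a real number where hydrogen at this position yields only a limit, and the change reads as an at least 1.3-fold lower number from compound 2 to compound 3 (0.12 log units; that floor lies within the scatter). This shows that the position accepts propyl with a measurable dose, although the step is only a floor that lies within the scatter. Its true size stays unknown because one end of it is a limit: the limit of > 200 mg/kg in this assay, at which 1 of the 3 values shown sits.

Going by these compounds, whether methyl, a longer chain such as hexyl, or a chain carrying an amine would shift the dose on this nitrogen remains open.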